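Working notes on Vero cytotoxicity: nitro substitution from compound 2

A few compounds are considered here, and "the series" means these few. Any claim that something is new, unique, unknown or untested is made for them only; others in the source may bear on it.

Compound 1 `Cc1ccc(C)n1-c1ccc(C(=O)N/N=C/c2ccccc2Cl)cc1` has no result in an ADME assay on Vero cells (Chlorocebus sabaeus) for cytotoxicity, read by MTT assay, with a stated time of 72 h; on this read-out higher numbers stand for weaker inhibition and lower numbers for stronger inhibition: for compound 1 the entry reads "not determined" (no result reported). Within the data shown here, compound 2 `O=C(NNC(=O)c1ccc(-n2cccc2)cc1)c1ccccc1` gives 200000 nM in this assay, which is the only number in hand for this series, so compound 2 cannot be ranked against anything measured. Compound 3 `O=C(NNC(=O)c1ccccc1[N+](=O)[O-])c1ccc(-n2cccc2)cc1` differs from compound 2 by nitro in place of hydrogen on an aromatic carbon. Among the measured compounds shown here, no step between two measured compounds exists to gauge this change, so the step is expected to stay within the usual scatter, without a fixed direction: no change at the digits printed from compound 2 to compound 3 (within the scatter). Compound 3 is therefore expected to give 200000 nM in this assay, with a range from 100000 nM to 400000 nM.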

Compound 3, half-maximal inhibitory concentration: 182000 nM
For compound 3 the middle estimate is 1.1-fold (0.04 log units) above the measured one; low and high end bracket the measured number.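

In this assay, among these compounds, nitro in place of hydrogen on an aromatic carbon, ortho to a large group, gives a 1.1-fold lower number from compound 2 to compound 3 (0.04 log units; within the scatter) as the first readable step, so this position takes a nitro group with the two values inside the scatter of each other. No supporting measurement offers a reason for this result and a single step sets no trend for the series.

As far as these compounds go, whether an amine or a carboxylic acid at this same place would also stay within the scatter remains open. Whether a larger group, such as a longer chain, would do the same is equally unsettled.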